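A few compounds are considered here, and "the series" means these few. Any claim that something is new, unique, unknown or untested is made for them only; others in the source may bear on it.

Of the compounds shown here, three have been measured in a functional assay on K562 cells (Homo sapiens) for antiproliferative activity, read by sulforhodamine B assay, with a stated time of 48 h, tested at 50 uM; a lower number here means less inhibition, a higher number more inhibition at the concentration tested (going by the name of the read-out). Compound 1 `CC1=CC[C@H](C(C)C)c2cc(C)c(OC(=O)Nc3ccccc3)cc21` is a carbamate built on one core; compound 3 `CC1=CC[C@H](C(C)C)c2cc(C)c(OC(=O)c3ccc(C(F)(F)F)cc3)cc21` carries an ester bearing a trifluoromethyl on that same core; compound 2 `Cc1cc2c(C(C)C)ccc(C)c2cc1OC(=O)c1ccc(C(F)(F)F)cc1` carries the same ester on a different core. In this assay compound 1 gives 92.6%, compound 3 gives 9% and compound 2 gives 45.1%. On these numbers compound 2 stands second highest of the three: its nearest neighbour is compound 3, which lies lower by an amount beyond the usual scatter, and the furthest is compound 1, which lies higher, again beyond the scatter.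

Compound 4 `COc1ccc(C(=O)Oc2cc3c(C)ccc(C(C)C)c3cc2C)cc1` keeps the core and the ester of compound 2 and differs only at one point: methoxy in place of trifluoromethyl on an aromatic carbon. Among the measured compounds shown here, no measured pair here shows what this exchange does on its own, so the expectation rests on the values of compound 2 and compound 3 alone, both esters of the same acid with modest to low inhibition. The expected step is a number 5.1 percentage points lower from compound 2 to compound 4 (within the scatter), small and close to or within the scatter, with no strong reason to foresee a marked rise or fall.

Taking compound 2 as the anchor, compound 4 is expected to give about 40%, within a range from 15% to 70%.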

Compound 4, a percentage reported as inhibition, at one concentration (the size of the read-out at that concentration, not a potency): 88.6%
Compound 4: middle estimate off by 48.6 percentage points, on the low side, and the stated range ends below it.
By their numbers in this assay, from the lowest: compound 3; then compound 2; then compounds 4 and 1 (each within the scatter of the next).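

In this assay, putting methoxy in place of trifluoromethyl on the aromatic carbon para to a large group gives a number 43.5 percentage points higher from compound 2 to compound 4 (beyond the scatter), so on this core the group at this one carbon can decide much of the inhibition seen at the tested concentration. The earlier compounds shown here could not show this, as both esters among them carry trifluoromethyl at this carbon and no pair isolated a change there. The step rests on a single pair and a single concentration, so it describes the size of the read-out rather than potency, and nothing available here bears on why the exchange has so large an effect.

From the compounds shown here alone, it remains open whether the same exchange would raise the number on the core of compound 3 as well, since a single pair on the core of compound 2 cannot show whether the step carries over to another core. Going by these compounds, it is also open where other groups on this carbon would fall relative to compound 2 and compound 4, for example an amine, a hydroxyl or a longer chain such as butoxy.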